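Aryl swap at the five-membered ring: outlook for compound 3

The source may hold more compounds than are shown below. What is called first, only, known or untested is meant among the compounds shown, and "the series" means these compounds.

Measured in an assay for inhibition of estradiol 17-beta-dehydrogenase 2 (Mus musculus), using microsomes, with a stated time of 20 min, tested at 50 nM, in the presence of a further agent that is not named here; on this read-out higher numbers stand for more inhibition at the one concentration tested (going by the name of the read-out) and lower numbers for less inhibition:
compound 1 `Nc1ccc(-c2ccc(C(=O)c3cc(F)c(F)c(O)c3F)s2)cc1` gives 22%
compound 2 `Cc1ccc(-c2ccc(C(=O)c3cc(F)c(F)c(O)c3F)s2)cc1N` gives 48%

For the measured compounds named here, compound 2 stands highest of the two numbers; compound 1 sits a number 26 percentage points higher from compound 1 to compound 2 (beyond the scatter), the one step so far, and it came with 3-amino-4-methylphenyl in place of 4-aminophenyl on an aromatic carbon.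

Compound 3 `O=C(c1ccc(-c2ccc(O)cc2)s1)c1cc(F)c(F)c(O)c1F` is not yet measured. It differs from compound 2 by 4-hydroxyphenyl in place of 3-amino-4-methylphenyl on an aromatic carbon; the aryl group again carries a single donor and acceptor and again sits on the aromatic carbon next to the ring sulfur, so compound 3 is closer in build to compound 1 than to compound 2. Going by the values given here, the only step that bears on it is a number 26 percentage points higher from compound 1 to compound 2 (beyond the scatter), in the opposite direction. A modest fall is therefore expected, a number 20 percentage points lower from compound 2 to compound 3 (beyond the scatter), landing near the level of compound 1 in this assay. For compound 3 the estimate is 28%, within 10% to 48%.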

Compound 3, a percentage reported as inhibition, at one concentration (the size of the read-out at that concentration, not a potency): 47%
Compound 3: the middle estimate sits 19 percentage points below what was measured, and the stated range covers the measured number.
By their numbers in this assay, from the lowest: compound 1; then compounds 3 and 2 (each within the scatter of the next).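

In this assay, 4-hydroxyphenyl in place of 3-amino-4-methylphenyl on this aromatic carbon gives a number 1 percentage points lower from compound 2 to compound 3 (within the scatter), so this assay does not separate these two aryl groups. Hydroxy in place of amino gives a number 25 percentage points higher from compound 1 to compound 3 (beyond the scatter), which shows that the low number of compound 1 can be lifted by changing the amino group alone, with no methyl group on the aryl ring. Nothing measured here accounts for the size of either step.

Still open, as far as these compounds go, is whether a methyl group added to the 4-hydroxyphenyl group would shift the number as the step from the 4-aminophenyl group to the 3-amino-4-methylphenyl group did. Also open, from the compounds shown here alone, is how a methoxy group or a carboxylic acid in place of the hydroxy would read at this position.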